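The source may report more compounds than this note shows. Statements on the series, on what has been measured and on what is new or still open speak of the compounds shown alone.

Measured so far:
compound 1, `COc1ncnc2c1c(-c1ccsc1)cn2[C@@H]1O[C@H](CO)[C@@H](O)[C@H]1O`, 130 nM
compound 2, `COc1nc(N)nc2c1c(-c1ccsc1)cn2[C@@H]1O[C@H](CO)[C@@H](O)[C@H]1O`, a limit only
compound 3, `O=c1[nH]cnc2c1c(-c1ccco1)cn2[C@@H]1O[C@H](CO)[C@@H](O)[C@H]1O`, 2200 nM

All three were tested in a functional assay on HL-60 cells (Homo sapiens) for antiproliferative activity, read by XTT assay, with a stated time of 72 h; a higher number here means a weaker inhibitor, a lower number a stronger inhibitor. Compound 1 gives 130 nM. For compound 2 this assay reports only a limit, > 20000 nM. Compound 3 gives 2200 nM, the highest of the two numbers.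

The change from compound 1 to compound 2 is amino in place of hydrogen on an aromatic carbon. It gave an at least 150-fold higher number from compound 1 to compound 2 (2.18 log units; beyond the scatter). The size of that step is bounded only from one side, because of the limit of > 20000 nM in this assay, at which 1 of the 3 values shown sits.

How the core of compound 3 differs from the core of compound 1 is not broken down here.

Compound 4, `Nc1nc2c(c(-c3ccco3)cn2[C@@H]2O[C@H](CO)[C@@H](O)[C@H]2O)c(=O)[nH]1`, has not yet been measured. It differs from compound 3 by amino in place of hydrogen on an aromatic carbon. Among the compounds with values here, this is the same kind of change as the one from compound 1 to compound 2, though the surroundings differ: here the new group sits meta to a group of 1 heavy atom, there meta to a methoxy group (2 heavy atoms).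

The step from compound 3 to compound 4 is expected to be large, an 18-fold higher number from compound 3 to compound 4 (1.26 log units; beyond the scatter), resting on the earlier at least 150-fold higher number from compound 1 to compound 2 (2.18 log units; beyond the scatter). Compound 4 is therefore expected to give 40000 nM, between 8000 nM and 200000 nM.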

Compound 4, half-maximal inhibitory concentration: > 20000 nM
Compound 4 gave a limit, no number; the forecaster's own chance of this, stated with the estimate: 70%; the middle value does not contradict the limit.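

In this assay compound 4 gives > 20000 nM as a limit and not as a number. Amino in place of hydrogen on the core of compound 3 still gives an at least 9.0-fold higher number from compound 3 to compound 4 (0.95 log units; beyond the scatter) and so makes the compound a clearly weaker inhibitor, which means the rise in the number seen on the core of compound 1 also appears on this second core. The direction of the change therefore carries over between these two cores, but its size does not carry over in any readable way, and the data cannot say whether the change costs more on one core than on the other: the same change on two cores in this assay, an at least 150-fold higher number (2.18 log units; beyond the scatter) from compound 1 to compound 2 and an at least 9.0-fold higher number (0.95 log units; beyond the scatter) from compound 3 to compound 4; the limit leaves it open whether they differ.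

The compounds shown leave open whether a smaller or different group on the same aromatic carbon between two ring nitrogen atoms, such as fluorine, methyl or methylamino, would be tolerated any better than amino. Also open is whether the same change would raise the number on a third core, as only two cores are shown here.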